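Dropping the chloro from compound 2: cytotoxicity notes

This account rests on a few compounds, and the source may have more. Where it says the series, first, only, none or still open, it means among the compounds named here.

In an ADME assay on Vero 76 cells (Chlorocebus sabaeus) for cytotoxicity, read by crystal violet staining, with a stated time of 96 h (on this read-out higher numbers stand for lower toxicity in this test and lower numbers for higher toxicity in this test), compound 1 `O=C(NC(=S)Nc1cccc(C(F)(F)F)c1)c1ccccc1` reaches only a limit, > 100000 nM. Two compounds give numbers: compound 2 `FC(F)(F)c1cccc(NC(=S)Nc2ccc(Cl)cc2)c1` reads 11000 nM and compound 3 `Fc1ccc(NC(=S)Nc2cccc(C(F)(F)F)c2)cc1Cl` reads 20000 nM. These two values lie within the usual scatter of each other, so compound 2 stands level with its nearest neighbour.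

Compound 4 `FC(F)(F)c1cccc(NC(=S)Nc2ccccc2)c1` awaits measurement. It carries hydrogen in place of chloro on an aromatic carbon, para to a large group (hydrogen in place of chloro on an aromatic carbon). For the measured compounds named here, no measured step isolates this change. A small rise in the number is expected, with the step of a 1.6-fold higher number from compound 2 to compound 4 (0.21 log units; within the scatter) estimated to stay within the scatter. For compound 4 the estimated value is 18000 nM, with an expected range of 7000 nM to 50000 nM.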

Compound 4, half-maximal cytotoxic concentration: 39000 nM
The estimate for compound 4 lay 2.2-fold (0.34 log units) below the measured number; the measured number falls inside the stated range.
By their numbers in this assay, from the lowest: compounds 2, 3 and 4 (each within the scatter of the next, the first and the last beyond it). At a limit, above all of these: compound 1.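

In this assay, for the compounds shown here, the chloro position gives the only readable step: hydrogen in place of chloro brings a 3.5-fold higher number from compound 2 to compound 4 (0.55 log units; beyond the scatter). Going by these compounds alone, at this place, para to a large group, the 4-chlorophenyl to phenyl change therefore goes with lower toxicity in this test, though only this one pair shows it. Compound 1 alone stands at a limit: the limit of > 100000 nM in this assay, at which 1 of the 4 values shown sits.

The pair gives no cause for the step. As far as these compounds go, whether a methoxy group, an amine or a carboxylic acid at this place would read nearer compound 2 or compound 4 remains open.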